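The compounds below may be only part of what the source reports. "The series", "measured", "known", "first", "only" and "open" are said of these compounds alone.

Series built on the shared core of compound 1 `Cn1cncc1C(OCc1ccc(C#N)cc1C#Cc1ccccn1)c1ccc(C#N)cc1`, varied only at the group on a triple-bonded carbon, and read in a functional assay on NIH3T3 cells (Mus musculus); on this read-out lower numbers stand for an effect already at smaller amounts and higher numbers for an effect only at larger amounts of compound. For compound 1 this assay reports only a limit, > 0.1 nM. Compound 2 `Cn1cncc1C(OCc1ccc(C#N)cc1C#Cc1ccc([N+](=O)[O-])cc1)c1ccc(C#N)cc1` carries 4-nitrophenyl at that carbon and gives 36 nM. Compound 3 `Cn1cncc1C(OCc1ccc(C#N)cc1C#Cc1cccc(O)c1)c1ccc(C#N)cc1` carries 3-hydroxyphenyl at the same carbon. For compound 3 this assay again reports only a limit, > 0.1 nM. The steps a step that the limit leaves unreadable from compound 1 to compound 2, a step that the two limits leave unreadable from compound 1 to compound 3 and a step that the limit leaves unreadable from compound 2 to compound 3 therefore cannot be sized from the values in hand; the limit of > 0.1 nM in this assay, at which 2 of the 3 values shown sit, leaves compound 1 without a fixed number to start from.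

Compound 4 `Cn1cncc1C(OCc1ccc(C#N)cc1C#CCCc1ccccc1)c1ccc(C#N)cc1` differs from compound 1 as follows: phenethyl in place of pyridin-2-yl on a triple-bonded carbon. For the measured compounds named here, none of the measured steps bears directly on this change, and the one fixed number in the set belongs to compound 2, while the other two values sit at the limit. For compound 4 the expected step from compound 1 is a step that the limit leaves unreadable from compound 1 to compound 4. For compound 4 the estimate in this assay is 5 nM, with a range from 0.1 nM to 100 nM, and a real chance that this assay once more returns only a limit.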

Compound 4, half-maximal effective concentration: 130 nM
Compound 4: middle estimate off by 26-fold (1.41 log units), on the low side; the measured number lies above the stated range.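

For the compounds shown here, compound 4 gives this position a second fixed number in this assay, and with it comes the first step that can be sized: a 3.6-fold higher number from compound 2 to compound 4 (0.56 log units; beyond the scatter). Phenethyl, with its ring of carbon only and 0 hydrogen-bond acceptors, therefore returns a number rather than a limit, and that number is higher than the one for 4-nitrophenyl by more than the usual scatter. The steps to compound 4 from compound 1 and from compound 3 cannot be read: the limit of > 0.1 nM in this assay, at which 2 of the 4 values shown sit.

Where compound 1 and compound 3 stand relative to compound 4 stays open. Also open, on these data alone, is how this assay responds at this triple-bonded carbon to a longer chain, or to a group carrying an amine or a carboxylic acid.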